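The source may report more compounds than this note shows. Statements on the series, on what has been measured and on what is new or still open speak of the compounds shown alone.

Measured so far:
- compound 1, `O=C1/C(=C/c2ccccc2F)CN(Cc2cn(Cc3ccc(F)cc3)nn2)C/C1=C\c1ccccc1F`: 10000 nM
- compound 2, `Cc1ccc(/C=C2\CN(Cc3cn(Cc4cccc(Cl)c4)nn3)C/C(=C\c3ccc(C)cc3)C2=O)cc1`: 9000 nM

Of the compounds shown here, two have been tested in a functional assay on MDA-MB-231 cells (Homo sapiens) for cytotoxicity, read by MTT assay, with a stated time of 24 h; a lower number here means a stronger inhibitor, a higher number a weaker inhibitor. Compound 1 gives 10000 nM, and compound 2 gives 9000 nM. These two numbers lie within the usual scatter of each other, so on the evidence so far neither compound can be called stronger or weaker than the other, and both sit at the weak end of what such an assay resolves.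

The next compound, compound 3, `O=C1/C(=C/c2ccccc2F)CN(Cc2cn(Cc3cccc(Cl)c3)nn2)C/C1=C\c1ccccc1F`, is compound 1 with a single change: 3-chlorophenyl in place of 4-fluorophenyl on a saturated chain carbon bound to an aromatic nitrogen. Compound 2 already carries a 3-chlorophenyl at this place and shows a value close to that of compound 1, which is the only hint available. No shift beyond the scatter is therefore expected from compound 1 to compound 3; the expected step is a 1.1-fold lower number from compound 1 to compound 3 (0.05 log units; within the scatter). Compound 3 is estimated at 9000 nM, within a range of 3500 nM to 22000 nM.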

Compound 3, half-maximal inhibitory concentration: 12000 nM
Estimate against measurement, compound 3: 1.3-fold (0.12 log units) below; low and high end bracket the measured number.
By their numbers in this assay, from the lowest: compounds 2, 1 and 3 (each within the scatter of the next).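

In this assay, going by these compounds alone, compounds 1 and 3 give the first comparison in which only one place differs: 3-chlorophenyl in place of 4-fluorophenyl on a saturated chain carbon bound to an aromatic nitrogen gives a 1.2-fold higher number from compound 1 to compound 3 (0.08 log units; within the scatter) and so does not separate the two compounds. At this position, then, the identity of the halogen and where it sits on the phenyl ring can be exchanged in this one way without a readable shift, on the core of compound 1. Nothing measured here explains this result.

The compounds shown leave open whether a phenyl ring carrying an amine or a carboxylic acid, or a longer chain in place of the ring, would move the number beyond the scatter. Going by these compounds, whether the same swap reads alike with other groups elsewhere on the shared core also remains open.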